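Phenoxy in Place of Methyl on a Shared Core

The source may hold more compounds than are shown below. What is called first, only, known or untested is meant among the compounds shown, and "the series" means these compounds.

Of the compounds shown here, three on one shared core have been measured in a functional assay on WI-38 VA13 cells (Homo sapiens) for cytotoxicity; a lower number here means that less compound is needed, a higher number that more compound is needed for the effect. Compound 1 `O=C(Nc1nc2ccc(NC(=O)C3CCCO3)cc2s1)C1CCCCC1` gives 1.3 ug/mL in this assay. Compound 2 `Cn1nccc1C(=O)Nc1ccc2nc(NC(=O)C3CCCCC3)sc2c1` gives 0.58 ug/mL in this assay. Compound 3 `CC(=O)Nc1nc2ccc(NC(=O)c3c(Cl)cccc3Cl)cc2s1` gives 0.6 ug/mL in this assay. Going by the values given here, the single step between compounds differing in one place, a 2.2-fold lower number from compound 1 to compound 2 (0.35 log units; beyond the scatter), exchanges the group on one carbonyl carbon. Compound 3 lies within the scatter of compound 2, and it shows a lower number than compound 1.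

Compound 4 `O=C(Nc1nc2ccc(NC(=O)c3c(Cl)cccc3Cl)cc2s1)Oc1ccccc1` differs from compound 3 by phenoxy in place of methyl on a carbonyl carbon. Among the compounds with values here, no measured step touches this carbonyl carbon; the only step available, a 2.2-fold lower number from compound 1 to compound 2 (0.35 log units; beyond the scatter), concerns the other carbonyl carbon and was modest. Given that the one comparable exchange moved the number only modestly, compound 4 is expected to stay near compound 3 in this assay, with no step beyond the scatter clearly foreseen. Compound 4 is therefore estimated at 0.6 ug/mL, with a range from 0.25 ug/mL to 1.5 ug/mL. This estimate means an expected step of no change at the digits printed from compound 3 to compound 4 (within the scatter).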

Compound 4, half-maximal effective concentration: 1.1 ug/mL
Estimate against measurement, compound 4: 1.8-fold (0.26 log units) below, and the stated range covers the measured number.
By their numbers in this assay, from the lowest: compounds 2, 3, 4 and 1 (each within the scatter of the next, the first and the last beyond it).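

Phenoxy in place of methyl on the carbonyl carbon whose other neighbour is an amide-type nitrogen gives a 1.8-fold higher number from compound 3 to compound 4 (0.26 log units; within the scatter) in this assay, the first reading at this position. Going by these compounds alone, the only earlier step, a 2.2-fold lower number from compound 1 to compound 2 (0.35 log units; beyond the scatter), lay on the other carbonyl carbon, so this result adds that acetamido can give way to (phenoxycarbonyl)amino, bringing in a six-membered aromatic ring and an added hydrogen-bond acceptor, without a step beyond the scatter. No available evidence bears on the reason for this result.

From the compounds shown here alone, whether an amine on this carbonyl carbon, or a longer alkyl chain, would also stay within the scatter of compound 3 remains open. So does whether phenoxy would behave in the same way with a different group on the other carbonyl carbon, such as cyclohexyl.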